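A Larger Amine at the Aromatic Carbon

This account rests on a few compounds, and the source may have more. Where it says the series, first, only, none or still open, it means among the compounds named here.

Compound 1, `CC(C(=O)NCc1ccc(C(F)(F)F)nc1NC1CCCCC1)c1ccc(NS(C)(=O)=O)c(F)c1`: 20.4 nM
Compound 2, `CC(C(=O)NCc1ccc(C(F)(F)F)nc1N(C)C)c1ccc(NS(C)(=O)=O)c(F)c1`: 19.1 nM

In a functional assay on CHO-K1 cells for antagonist activity at transient receptor potential cation channel subfamily V member 1 (Homo sapiens), read by FLIPR (a higher number here means a weaker inhibitor, a lower number a stronger inhibitor), compound 1 gives 20.4 nM and compound 2 gives 19.1 nM. Compound 2 has the smaller of the two numbers, but the step of a 1.1-fold lower number from compound 1 to compound 2 (0.03 log units; within the scatter) shows that the two values cannot be told apart. Both compounds share one core and differ only in the amine attached to the aromatic carbon.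

Compound 3, `CC(C(=O)NCc1ccc(C(F)(F)F)nc1N1CCC(CN(C)C)CC1)c1ccc(NS(C)(=O)=O)c(F)c1`, is not yet measured. It differs from compound 2 in one place: 4-((dimethylamino)methyl)piperidin-1-yl in place of dimethylamino on an aromatic carbon. Going by the values given here, only one measured step touches this position, a 1.1-fold lower number from compound 1 to compound 2 (0.03 log units; within the scatter), where a cyclohexylamino group and a dimethylamino group gave the same result within the scatter. That single step suggests the position tolerates groups of quite different size, so the step of a 1.3-fold higher number from compound 2 to compound 3 (0.12 log units; within the scatter) is expected to be small, with no clear direction. The estimate for compound 3 in this assay is therefore 25 nM, expected to fall between 8 nM and 80 nM.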

Compound 3, inhibition constant: 2.1 nM
Compound 3: the middle estimate sits 12-fold (1.08 log units) above what was measured; measured number outside the range, below it.
By their numbers in this assay, from the lowest: compound 3; then compounds 2 and 1 (each within the scatter of the next).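

In this assay, the swap from cyclohexylamino to dimethylamino had suggested that this position, on an aromatic carbon next to the ring nitrogen, responds little to what is attached there, but the 4-((dimethylamino)methyl)piperidin-1-yl group changes that picture, with steps beyond the scatter from both earlier compounds (a 9.1-fold lower number from compound 2 to compound 3 (0.96 log units; beyond the scatter)) and (a 9.7-fold lower number from compound 1 to compound 3 (0.99 log units; beyond the scatter)). Size and the presence of a ring do not tell the whole story: compound 1 also carries a ring at this position, yet its number lies within the scatter of that of compound 2, while compound 3 carries a ring with a nitrogen in it and a side chain ending in a dimethylamino group. No measurement shown here accounts for the lower number of compound 3.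

The compounds shown leave open which part of the new group goes with the change, and a plain piperidin-1-yl group would separate the ring from the side chain. Also open, going by these compounds, is whether a longer chain between the ring and the dimethylamino group, or a carboxylic acid in place of that amine, would keep the number this low.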